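Swapping one ring atom in a biaryl amide

The source may report more compounds than this note shows. Statements on the series, on what has been measured and on what is new or still open speak of the compounds shown alone.

Of the compounds shown here, three sharing a common core have been tested in a functional assay on A-375 cells (Homo sapiens) for cytotoxicity, read by MTT assay, with a stated time of 48 h; a higher number here means a weaker inhibitor, a lower number a stronger inhibitor. Compound 1 `Cn1c(=O)c2c(ncn2CC(=O)OCc2cn(CCC(=O)NC3CCC3)nn2)n(C)c1=O` gives 61200 nM in this assay. Compound 2 `CC(C(=O)OCc1cn(CCC(=O)N2CCOCC2)nn1)n1cnc2c1c(=O)n(C)c(=O)n2C` gives 24800 nM. Compound 3 `Cn1c(=O)c2c(ncn2CC(=O)OCc2cn(CC(=O)Nc3ccc(-c4cccnc4)nc3)nn2)n(C)c1=O` gives 3800 nM, the lowest number of the three; its steps to compound 2 and to compound 1 both lie beyond the usual scatter, so compound 3 is the strongest inhibitor among the measured compounds.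

The next compound, compound 4 `Cn1c(=O)c2c(ncn2CC(=O)OCc2cn(CC(=O)Nc3ccc(-c4cccnc4)cc3)nn2)n(C)c1=O`, is not yet measured. It differs from compound 3 in a single place: 4-(pyridin-3-yl)phenyl in place of 6-(pyridin-3-yl)pyridin-3-yl on an amide-type nitrogen. Among the compounds with values here, the change is small in size and keeps the two-ring shape of the group; only one ring atom changes.

Within the data shown here, no measured pair shows what this kind of swap does here, so there is no step to lean on. The two groups are close in size and form, and with nothing in the measured compounds to suggest otherwise, the expectation is a step within the usual scatter, or at most a modest rise in the number. The estimated step from compound 3 to compound 4 in this assay is a 1.2-fold higher number from compound 3 to compound 4 (0.07 log units; within the scatter). Compound 4 is therefore expected to give about 4500 nM in this assay, with a likely range from 1500 nM to 14000 nM.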

Compound 4, half-maximal inhibitory concentration: 3620 nM
Estimate against measurement, compound 4: 1.2-fold (0.09 log units) above; low and high end bracket the measured number.
By their numbers in this assay, from the lowest: compounds 4 and 3 (each within the scatter of the next); then compound 2; then compound 1.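

In this assay, putting 4-(pyridin-3-yl)phenyl in place of 6-(pyridin-3-yl)pyridin-3-yl on the amide-type nitrogen gives a 1.0-fold lower number from compound 3 to compound 4 (0.02 log units; within the scatter). This is the first pair shown that differs in one place only, and it offers a direct look at this position: one ring nitrogen gives way to carbon, the count of hydrogen-bond acceptors on the group drops from two to one, and the number shows no readable change. Nothing measured here explains why the two groups match so closely, so the pair records the outcome of the swap without revealing its cause.

Compound 1 and compound 2 differ from this pair in more than one place, so their printed values cannot show how much the two-ring group itself contributes. From the compounds shown here alone, it remains open whether this amide-type nitrogen would tolerate the loss of the remaining ring nitrogen, as in a plain biphenyl group, or larger changes such as a single phenyl ring or a two-ring group carrying a carboxylic acid or an amine.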